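Replacing the Nitrile-Bearing Aryl Group with a Dichlorophenyl

The source may report more compounds than this note shows. Statements on the series, on what has been measured and on what is new or still open speak of the compounds shown alone.

Compound 1 `N#Cc1ccc(-n2nc(-c3ccc(C(F)(F)F)cc3O)nc2-c2ccccc2O)cc1` is tested in a functional assay on PC-12 cells (Rattus norvegicus) for cytotoxicity, read by MTT assay, with stated times of 2 h and 24 h, tested at 10 uM (on this read-out lower numbers stand for a weaker effect and higher numbers for a stronger effect at the one concentration tested), where compound 1 gives 98.9%. That is the lowest of the three numbers measured, though both of the other two lie within the usual scatter of it. Compound 2 `COc1cccc(-n2nc(-c3ccc(C(F)(F)F)cc3O)nc2-c2ccccc2O)c1` gives 106% in this assay, and compound 3 `Cc1ccc(-n2nc(-c3ccc(C(F)(F)F)cc3O)nc2-c2ccccc2O)c(C)c1` gives 106%. The steps between them are small: a number 7.1 percentage points higher from compound 1 to compound 2 (within the scatter), a number 7.1 percentage points higher from compound 1 to compound 3 (within the scatter), and no change at the digits printed from compound 2 to compound 3 (within the scatter). Each of these steps exchanges the aryl group on the aromatic nitrogen while the rest of the shared core stays the same, and none of them moves this assay beyond the scatter.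

Compound 4 `Oc1cc(C(F)(F)F)ccc1-c1nc(-c2ccccc2O)n(-c2ccc(Cl)cc2Cl)n1` differs from compound 1 in the same place: 2,4-dichlorophenyl in place of 4-cyanophenyl on an aromatic nitrogen. Since every measured exchange at this position left this assay essentially unchanged, the expected step of a number 4.1 percentage points higher from compound 1 to compound 4 (within the scatter) is estimated to stay within the scatter. Compound 4 is therefore expected to give about 103% in this assay, with a likely range from 92% to 114%.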

Compound 4, a percentage reported as activity, at one concentration (the size of the read-out at that concentration, not a potency): 95.2%
The estimate for compound 4 lay 7.8 percentage points above the measured number; the range from low to high includes it.
By their numbers in this assay, from the lowest: compounds 4, 1, 2 and 3 (each within the scatter of the next, the first and the last beyond it).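

In this assay, for the compounds shown here, the 2,4-dichlorophenyl group gives the only steps at this aromatic nitrogen that pass the scatter: a number 10.8 percentage points lower from compound 2 to compound 4 (beyond the scatter) and a number 10.8 percentage points lower from compound 3 to compound 4 (beyond the scatter), both modest. Set against the 4-cyanophenyl group, the same group makes no clear difference, with a number 3.7 percentage points lower from compound 1 to compound 4 (within the scatter), so the position responds to some aryl exchanges, but only slightly. Nothing measured here accounts for these differences.

Going by these compounds, all four groups at this position are substituted phenyl rings, so it remains open whether a group of another kind, such as a plain butyl chain, a phenyl ring bearing an amine or one bearing a carboxylic acid, would move this read-out more. Also open, on these data alone, is whether the modest steps would hold at other concentrations.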